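A few compounds are considered here, and "the series" means these few. Any claim that something is new, unique, unknown or untested is made for them only; others in the source may bear on it.

Three compounds sharing one core have been examined in an ADME assay on microsomes from liver (Homo sapiens) for metabolic stability, read by LC-MS, tested at 1 uM; a lower number here means slower removal, a higher number faster removal of the compound. Compound 1 `NCCCCCOc1ccc([C@H]2CC[C@]3(CC2)OOC2(O3)C3CC4CC(C3)CC2C4)cc1` carries a (5-aminopentyl)oxy group on an aromatic carbon. In this assay compound 1 gives < 7 mL.min-1.g-1, which is a limit of the assay rather than a number. Compound 2 `O=S(=O)(c1ccc([C@H]2CC[C@]3(CC2)OOC2(O3)C3CC4CC(C3)CC2C4)cc1)N1CCNCC1` bears a (piperazin-1-yl)sulfonyl group in its place, and in this assay compound 2 gives 16 mL.min-1.g-1. That step, an at least 2.2-fold higher number from compound 1 to compound 2 (0.35 log units; beyond the scatter), is beyond the scatter. Compound 3 `NCCOc1ccc([C@H]2CC[C@]3(CC2)OOC2(O3)C3CC4CC(C3)CC2C4)cc1` shortens the chain to 2-aminoethoxy. In this assay compound 3 gives < 7 mL.min-1.g-1, again a limit of the assay. From compound 2 the number falls: an at least 2.2-fold lower number from compound 2 to compound 3 (0.35 log units; beyond the scatter). The two limits leave a step that the two limits leave unreadable from compound 1 to compound 3. Compound 1 thus stands at the floor of the numbers shown, (the limit of < 7 mL.min-1.g-1 in this assay, at which 2 of the 3 values shown sit).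

Compound 4 `c1cc([C@H]2CC[C@]3(CC2)OOC2(O3)C3CC4CC(C3)CC2C4)ccc1OCCOC1CCNCC1` has not yet been measured. It differs from compound 1 by (piperidin-4-yl)oxy in place of 3-aminopropyl on a saturated chain carbon, two bonds along the chain from an oxygen on an aromatic ring. Among the compounds with values here, no measured step touches a (piperidin-4-yl)oxy group; the two readable steps both run through compound 2 and its (piperazin-1-yl)sulfonyl group. Within the data shown here, the only guide is that compound 1 and compound 3, which both keep an amino-bearing chain on the aromatic oxygen, give no number. Compound 4 is therefore expected to stay near the low end, so that an at least 1.1-fold higher number from compound 1 to compound 4 (0.05 log units; that floor lies within the scatter) is expected to be small. The estimate for compound 4 is 8 mL.min-1.g-1, between 4 mL.min-1.g-1 and 20 mL.min-1.g-1.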

Compound 4, intrinsic clearance in microsomes: < 7 mL.min-1.g-1
Compound 4: only a limit was reported; the forecaster's own chance of this, stated with the estimate: 45%; middle value at least 1.1-fold (0.05 log units) from the limit.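

In this assay compound 4 gives < 7 mL.min-1.g-1, which is a limit of the assay and not a number. The limit therefore holds not only for the open chains ending in an amine but also for a chain carrying the larger (piperidin-4-yl)oxy group with its six-membered non-aromatic ring, and the fall from the (piperazin-1-yl)sulfonyl group persists with this group in place: an at least 2.2-fold lower number from compound 2 to compound 4 (0.35 log units; beyond the scatter). The steps linking compound 4 to compound 1 and compound 3 cannot be read, so all three ether-linked compounds share one floor, with compound 2 the only one that goes against this pattern: the limit of < 7 mL.min-1.g-1 in this assay, at which 3 of the 4 values shown sit.

From the compounds shown here alone, whether compound 1, compound 3 and compound 4 differ from one another beneath that limit remains open. Also open, going by these compounds, is whether the higher number of compound 2 goes with its sulfonyl link or with its piperazine, and whether the floor would hold for a chain on the aromatic oxygen that ends in a carboxylic acid or an amide instead of an amine.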